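Chloro Substitution on the Core and Solubility at Low pH

This account rests on a few compounds, and the source may have more. Where it says the series, first, only, none or still open, it means among the compounds named here.

In a physicochemical assay for solubility, at pH 2 (on this read-out higher numbers stand for higher solubility and lower numbers for lower solubility), compound 1 `CC(C)Nc1nc(NCc2ccco2)c2ccccc2n1` sits at a limit of >= 30000 nM, so where it stands is known only as a limit. Compound 2 `CC(C)Nc1nc(N(C)C)c2ccccc2n1` also gives only a limit of >= 30000 nM. Compound 3 `CC(C)Nc1nc(NCc2ccco2)c2cccc(Cl)c2n1` likewise gives only a limit of >= 30000 nM. The steps a step that the two limits leave unreadable from compound 1 to compound 2 and a step that the two limits leave unreadable from compound 1 to compound 3 therefore have no readable size, since all three values sit at the limit of >= 30000 nM in this assay, at which 3 of the 3 values shown sit. Compound 4 `CC(C)Nc1nc(NCc2ccco2)c2ccc(Cl)cc2n1` differs from compound 1 by chloro in place of hydrogen on an aromatic carbon. The closest comparison, the step from compound 1 to compound 3, is also a chloro entering the shared core, yet it gives no readable size or direction. For compound 4 the expected step is a step that the limit leaves unreadable from compound 1 to compound 4, with no readable direction beyond the scatter. Compound 4 is estimated at 40000 nM, within 15000 nM to 150000 nM.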

Compound 4, solubility: >= 30000 nM
Compound 4: a limit, no number; the forecaster's own chance of this, stated with the estimate: 80%; the middle value is on the limit's open side.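

Compound 1 and compound 4 both give only a limit in this assay, so no step between them can be read: the limit of >= 30000 nM in this assay, at which 4 of the 4 values shown sit.

The compounds shown leave open how far each lies beyond that limit, and whether chloro in place of hydrogen on an aromatic carbon shifts the read-out at all.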